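Swapping the urea aryl group in a kinase-like scaffold

The source may report more compounds than this note shows. Statements on the series, on what has been measured and on what is new or still open speak of the compounds shown alone.

Two urea compounds have been tested in a functional assay on NCI-H226 cells (Homo sapiens) for inhibition, read by MTT assay, with a stated time of 48 h, tested at 10 uM; a lower number here means less inhibition, a higher number more inhibition at the concentration tested (going by the name of the read-out). Compound 2 `COc1cc(Br)ccc1Nc1cc(NC(=O)Nc2c(Cl)cccc2Cl)ncn1` gives 43%. Compound 1 `COc1cc(NC(=O)Nc2cc(Nc3cc(F)ccc3OC)ncn2)cc(OC)c1` gives 37.7%, and the two readings lie within the usual scatter of each other. Compound 3 `COc1cc(NC(=O)Nc2cc(Nc3ccc(Br)cc3OC)ncn2)cc(OC)c1` has not yet been measured; compared with compound 2 it carries 3,5-dimethoxyphenyl in place of 2,6-dichlorophenyl on an amide-type nitrogen. The step from compound 2 to compound 3 is expected to be small, a number 4 percentage points lower from compound 2 to compound 3 (within the scatter), with no clear direction beyond the scatter, because compound 1 with the same dimethoxyphenyl gives 37.7%. Compound 3 is therefore estimated at 39%, in a range from 20% to 58%.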

Compound 3, a percentage reported as inhibition, at one concentration (the size of the read-out at that concentration, not a potency): 25.7%
For compound 3 the middle estimate is 13.3 percentage points above the measured one; the measured number falls inside the stated range.
By their numbers in this assay, from the lowest: compound 3; then compounds 1 and 2 (each within the scatter of the next).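

On the amide-type nitrogen, 3,5-dimethoxyphenyl in place of 2,6-dichlorophenyl is not a neutral swap: in this assay it gives a number 17.3 percentage points lower from compound 2 to compound 3 (beyond the scatter). The other end counts as well, since 4-bromo-2-methoxyphenyl in place of 5-fluoro-2-methoxyphenyl on a nitrogen on an aromatic ring gives a number 12 percentage points lower from compound 1 to compound 3 (beyond the scatter). Nothing available explains either step. Going by these compounds, how a cyclohexyl group or a pyridine ring would read on the amide-type nitrogen stays open. Also open, on these data alone, is whether 2,6-dichlorophenyl keeps its higher number alongside 5-fluoro-2-methoxyphenyl.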